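Bis-sulfonamide anilines sitting at the assay ceiling

A few compounds are considered here, and "the series" means these few. Any claim that something is new, unique, unknown or untested is made for them only; others in the source may bear on it.

Compound 1 `Cc1ccc(S(=O)(=O)Nc2ccc(NS(=O)(=O)c3ccc(F)c(F)c3)cc2)cc1` was tested in an assay for inhibition of liver carboxylesterase 1 (Homo sapiens), read by spectrophotometry; a lower number here means a stronger inhibitor, a higher number a weaker inhibitor. In this assay compound 1 gives > 100000 nM, which is a limit of the assay rather than a number. Compound 3 `O=S(=O)(Nc1ccc(NS(=O)(=O)c2ccc(F)c(F)c2)cc1)c1ccccc1` gives > 100000 nM, again a limit. Compound 2 `Cc1c(C)c(NS(=O)(=O)c2cccc(Cl)c2)c(C)c(C)c1NS(=O)(=O)c1cccc(Cl)c1` gives > 100000 nM, also a limit. Among the compounds with values here, the one single-point step among them, a step that the two limits leave unreadable from compound 1 to compound 3, cannot be read in size, since both of its ends sit at the limit (the limit of > 100000 nM in this assay, at which 3 of the 3 values shown sit). Compound 4 `Cc1ccc(S(=O)(=O)Nc2ccc(NS(=O)(=O)c3ccc(Cl)cc3)cc2)cc1` differs from compound 1 by 4-chlorophenyl in place of 3,4-difluorophenyl on a sulfonyl sulfur. Within the data shown here, no measured step bears on this exchange, and every value shown sits at the same limit, so no step beyond the scatter is expected in this assay. Compound 4 is expected to give 150000 nM, between 40000 nM and 600000 nM, most probably reported again only as a limit. The step that the limit leaves unreadable from compound 1 to compound 4 is accordingly expected to be slight.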

Compound 4, inhibition constant: > 100000 nM
Compound 4: only a limit was reported (the forecaster's own chance of this, stated with the estimate: 85%); the middle value is on the limit's open side.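

The step from compound 1 to compound 4, 4-chlorophenyl in place of 3,4-difluorophenyl, cannot be read in size, since both ends are limits: the limit of > 100000 nM in this assay, at which 4 of the 4 values shown sit.

The compounds shown leave open whether any change to the shared core would give a readable value in this assay.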